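Compound 3 to compound 4: one acyl group exchanged

A few compounds are considered here, and "the series" means these few. Any claim that something is new, unique, unknown or untested is made for them only; others in the source may bear on it.

In an ADME assay on HepG2 2.2.15 cells (Homo sapiens) for cytotoxicity (on this read-out lower numbers stand for higher toxicity in this test and higher numbers for lower toxicity in this test), compound 1 `N#CCC(=O)OCCc1c(-c2ccccc2Cl)c2cc(Cl)ccc2[nH]c1=O` gives 100000 nM, compound 2 `COCC(=O)OCCc1c(-c2ccccc2Cl)c2cc(Cl)ccc2[nH]c1=O` gives 74000 nM and compound 3 `O=C(CCC1CCCCC1)OCCc1c(-c2ccccc2Cl)c2cc(Cl)ccc2[nH]c1=O` gives 160000 nM. Two steps place the last of these: a 1.6-fold higher number from compound 1 to compound 3 (0.20 log units; within the scatter) and a 2.2-fold higher number from compound 2 to compound 3 (0.33 log units; beyond the scatter). The remaining step is a 1.4-fold lower number from compound 1 to compound 2 (0.13 log units; within the scatter).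

Compound 4 `CC(=O)N1CCC(C(=O)OCCc2c(-c3ccccc3Cl)c3cc(Cl)ccc3[nH]c2=O)CC1` has not been measured. It carries 1-acetylpiperidin-4-yl in place of 2-cyclohexylethyl on a carbonyl carbon.

Among the compounds with values here, the three measured steps all change the same side chain and bear on this exchange only indirectly, as no measured compound carries the entering group. Within the data shown here, the one step beyond the scatter is modest, and swapping cyano, methoxy and cyclohexylmethyl on the saturated chain carbon has produced nothing larger. A small step is therefore the reasonable expectation, with compound 4 falling among its three neighbours rather than outside them. The data offer no direct test of a ring with a hetero atom at this place, so the range is kept wide.

The expected size of the change in this assay is a 1.6-fold lower number from compound 3 to compound 4 (0.20 log units; within the scatter). For compound 4 the estimated value is 100000 nM, with an expected range of 50000 nM to 200000 nM.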

Compound 4, half-maximal cytotoxic concentration: 82000 nM
Beside the measured number, compound 4's estimate is 1.2-fold (0.09 log units) above it; measured number inside the range.
By their numbers in this assay, from the lowest: compounds 2, 4, 1 and 3 (each within the scatter of the next, the first and the last beyond it).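

In this assay the acyl position now holds a ring with a hetero atom, and the exchange of 2-cyclohexylethyl for 1-acetylpiperidin-4-yl stays within the scatter (a 2.0-fold lower number from compound 3 to compound 4 (0.29 log units; within the scatter)). Compound 4 also stays within the scatter of the methoxymethyl and cyanomethyl compounds (a 1.1-fold higher number from compound 2 to compound 4 (0.04 log units; within the scatter); a 1.2-fold lower number from compound 1 to compound 4 (0.09 log units; within the scatter)), so among these four compounds only one step lies beyond the scatter, and it is modest (a 2.2-fold higher number from compound 2 to compound 3 (0.33 log units; beyond the scatter)), leaving this place on the carbonyl carbon with little separation so far across open chains and six-membered rings. Nothing in the available data gives a reason for this narrow spread.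

Left open is whether a free piperidine amine without the acetyl, a carboxylic acid on the acyl group or a longer chain would stay within this same narrow spread in this assay. Also open, going by these compounds, is whether a phenyl ring on the carbonyl carbon would separate from compound 4, and whether the flat picture holds on any core other than the shared one.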